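Methoxy for fluoro on the benzyl ring

This account rests on a few compounds, and the source may have more. Where it says the series, first, only, none or still open, it means among the compounds named here.

Measured so far in a functional assay on A549 cells (Homo sapiens) for inhibition, read by MTT assay, with a stated time of 72 h; on this read-out lower numbers stand for stronger inhibition and higher numbers for weaker inhibition
Compound 1 `O=C1/C(=C\c2ccccc2)c2c(ncn2COCc2ccccc2)CCN1Cc1ccccc1` gives 9900 nM
Compound 2 `O=C1/C(=C\c2ccccc2)c2c(ncn2COCc2ccccc2)CCN1Cc1ccc(F)cc1` gives 19600 nM
Compound 3 `O=C1/C(=C\c2ccccc2)c2c(ncn2COCc2ccccc2)CCN1Cc1ccc(Cl)cc1` gives 11800 nM

Compound 2 cannot be separated from the other two compounds, since its steps to them stay within the usual scatter of repeated measurements. Compound 4 `COc1ccc(CN2CCc3ncn(COCc4ccccc4)c3/C(=C/c3ccccc3)C2=O)cc1` has not yet been measured. It differs from compound 2 by one change, (methoxy in place of fluoro on an aromatic carbon), which is methoxy in place of fluoro on an aromatic carbon, para to a large group.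

Among the measured compounds shown here, three measured steps bear on this, all swapping the group at that same place: a 2.0-fold higher number from compound 1 to compound 2 (0.30 log units; within the scatter), a 1.2-fold higher number from compound 1 to compound 3 (0.08 log units; within the scatter) and a 1.7-fold lower number from compound 2 to compound 3 (0.22 log units; within the scatter). None of them goes beyond the scatter. For the measured compounds named here, no measured compound carries methoxy, so the guide is hydrogen, fluoro and chloro only, and methoxy could still behave differently. Since compound 1 at 9900 nM and compound 3 at 11800 nM show no real change from that swapping, no step beyond the scatter is expected in this assay here. The estimate is a 1.5-fold lower number from compound 2 to compound 4 (0.18 log units; within the scatter), drawn toward the middle of the three values. For compound 4 the expected value is 13000 nM, with an estimated range from 6000 nM to 30000 nM as its likely span.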

Compound 4, half-maximal inhibitory concentration: 46800 nM
Compound 4: middle estimate off by 3.6-fold (0.56 log units), on the low side, and the stated range ends below it.
By their numbers in this assay, from the lowest: compounds 1, 3 and 2 (each within the scatter of the next); then compound 4.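

In this assay, this position no longer looks indifferent to what it carries: hydrogen, fluoro and chloro could not be told apart, but methoxy gives clearly weaker inhibition, with (a 4.7-fold higher number from compound 1 to compound 4 (0.67 log units; beyond the scatter)) when it replaces hydrogen. The same direction appears against both halogen compounds, with (a 4.0-fold higher number from compound 3 to compound 4 (0.60 log units; beyond the scatter)) for methoxy in place of chloro and (a 2.4-fold higher number from compound 2 to compound 4 (0.38 log units; beyond the scatter)) for methoxy in place of fluoro, so compound 4 stands apart from all three others, although each step is modest. Nothing available accounts for this separation, so the change in the numbers can be described here but not explained.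

Methoxy brings a carbon and an oxygen where fluoro has a single fluorine, and one compound cannot show whether the oxygen, the extra atom or the group as a whole matters. Hydroxyl, ethoxy or an amine at this same position would help to separate these possibilities, and it remains open whether the step seen with methoxy would carry over to a compound with a different group elsewhere on the shared core.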